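The source may hold more compounds than are shown below. What is called first, only, known or untested is meant among the compounds shown, and "the series" means these compounds.

Measured so far:
Compound 1, `COc1ccc(Cl)c(-c2nnc3n2NC(c2ccco2)S3)c1`: 13.9%
Compound 2, `COc1ccc(Cl)c(-c2nnc3n2NC(c2ccc[nH]2)S3)c1`: 12.8%

Both numbers come from a functional assay on the whole organism (strain Wistar Albino) for inhibition, with Rattus norvegicus as the target, read by paw edema, with a stated time of 1 h, at a dose of 20 mg/kg; on this read-out higher numbers stand for more inhibition at the one dose given (going by the name of the read-out) and lower numbers for less inhibition. For the measured compounds named here, compound 2 stands at the lower of the two values, with compound 1 as its only neighbour, and the step of a number 1.1 percentage points lower from compound 1 to compound 2 (within the scatter) lies within the usual scatter of this kind of measurement. The two compounds therefore cannot be told apart on the numbers shown.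

Compound 3, `COc1ccc(Cl)c(-c2nnc3n2NC(c2cccn2C)S3)c1`, is the next candidate. It differs from compound 2 by methyl in place of hydrogen on an aromatic nitrogen. Going by the values given here, no measured step involves a methyl on this aromatic nitrogen, so there is nothing that bears directly on the change. Among the compounds with values here, the only step available, a number 1.1 percentage points lower from compound 1 to compound 2 (within the scatter), concerns a different change at the saturated ring carbon and was itself within the scatter, so it gives no hint of a direction. On that basis the step of a number 0.2 percentage points higher from compound 2 to compound 3 (within the scatter) is expected to stay within the scatter, in no particular direction. Compound 3 is estimated at 13% in this assay, with a range from 4% to 23%.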

Compound 3, a percentage reported as inhibition, in the whole organism at one dose (the size of the read-out at that dose, not a potency): 14.1%
Estimate against measurement, compound 3: 1.1 percentage points below; the range from low to high includes it.
By their numbers in this assay, from the lowest: compounds 2, 1 and 3 (each within the scatter of the next).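

In this assay, this first look at a methyl on the aromatic nitrogen of the five-membered ring gives a number 1.3 percentage points higher from compound 2 to compound 3 (within the scatter), so at this dose the hydrogen and the methyl cannot be told apart. Comparing 1-methyl-1H-pyrrol-2-yl with furan-2-yl on the saturated ring carbon gives a number 0.2 percentage points higher from compound 1 to compound 3 (within the scatter), so this pair cannot be told apart either, and the three compounds now form a set in which each value lies within the scatter of the next. Nothing available here accounts for this result or bears on it.

The compounds shown change only this one ring substituent on the shared core, and a single methyl is the only group tried on the aromatic nitrogen, so they leave open whether any group at this place would produce a difference larger than the scatter. A longer chain such as n-butyl on that nitrogen, or a carboxylic acid or an amine carried on the same ring, would put that question to the test.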